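The source may hold more compounds than are shown below. What is called first, only, known or untested is meant among the compounds shown, and "the series" means these compounds.

Among the compounds with values here, in an assay on membranes from Chem-1 cells for displacement of a labelled ligand from prostaglandin E2 receptor EP3 subtype (Homo sapiens), read by scintillation counting, with a stated time of 2 h (on this read-out higher numbers stand for weaker inhibition and lower numbers for stronger inhibition), compound 1 `CC(C)C(CC1C(=O)NC(=O)N1C)c1ccc(-c2ccc3cccc(F)c3c2)[nH]c1=O` gives 17 nM, the second highest of the three numbers measured so far. Compound 2 `CCC(/C=C1\OC(=O)NC1=O)(CC)c1ccc(-c2ccc3cccc(F)c3c2)[nH]c1=O` gives 13 nM in this assay, a value that lies within the usual scatter of compound 1. Compound 3 `CC(C)/C(=C1\C(=O)NC(=O)N1C)c1ccc(-c2ccc3cccc(F)c3c2)[nH]c1=O` gives 85 nM in this assay, a weaker result that stands beyond the scatter from compound 1.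

Compound 4 `CC(C)C(/C=C1/C(=O)NC(=O)N1C)c1ccc(-c2ccc3cccc(F)c3c2)[nH]c1=O` has not yet been measured. Relative to compound 1 it carries a group of 9 heavy atoms (5 carbon, 2 nitrogen, 2 oxygen; one five-membered non-aromatic ring with 2 hetero atoms) in place of a group of 9 heavy atoms (5 carbon, 2 nitrogen, 2 oxygen; one five-membered non-aromatic ring with 2 hetero atoms), on a saturated chain carbon bound to an aromatic carbon and a saturated chain carbon; the group that enters holds one more double bond outside the ring than the group that leaves. Compound 2 carries a related exocyclic double bond and stays close to compound 1, while compound 3, whose double bond sits directly on the chain carbon, is the weaker one. Compound 4 is therefore expected to remain near compound 1, with a step of a 1.1-fold lower number from compound 1 to compound 4 (0.05 log units; within the scatter) that stays within the scatter in this assay. The estimate for compound 4 in this assay is 15 nM, expected to fall between 5 nM and 45 nM.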

Compound 4, inhibition constant: 6 nM
Compound 4: middle estimate off by 2.5-fold (0.40 log units), on the high side; the range from low to high includes it.
By their numbers in this assay, from the lowest: compound 4; then compounds 2 and 1 (each within the scatter of the next); then compound 3.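

In this assay, the exchange on the saturated chain carbon bound to an aromatic carbon and a saturated chain carbon gives a 2.8-fold lower number from compound 1 to compound 4 (0.45 log units; beyond the scatter) and this modest step lies beyond the scatter. Within the data shown here, it is the only step here between compounds that differ in one place, and it shows that this position responds to a change that leaves the heavy-atom count, the five-membered ring and the counted hydrogen-bond donors and acceptors the same, while adding one double bond outside the ring. No measurement shown bears on what lies behind this step.

As far as these compounds go, whether a carboxylic acid or an amine at this position would keep the lower number remains open. A single step also leaves open whether the added double bond would have the same effect with a longer chain on the saturated carbon.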